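The source may report more compounds than this note shows. Statements on the series, on what has been measured and on what is new or still open speak of the compounds shown alone.

In a physicochemical assay for acid dissociation, compound 1 (`COC(=O)c1cc(S(N)(=O)=O)ccc1S(=O)(=O)CCCO`) gives 8.9 and compound 2 (`CC(=O)OCCS(=O)(=O)c1ccc(S(N)(=O)=O)s1`) gives 8.65, so compound 2 stands within the usual scatter of compound 1. Compound 3 (`NS(=O)(=O)c1ccc(S(=O)(=O)CCCCO)s1`) keeps the core of compound 2 but carries 2-hydroxyethyl in place of acetoxy on a saturated chain carbon, two bonds along the chain from a sulfonyl sulfur. Going by the values given here, no measured pair shows this change, so no step beyond the scatter is expected in this assay, and the estimated step is a number 0.10 log units higher from compound 2 to compound 3 (within the scatter). For compound 3 the expected value is 8.75, with a range of 8.45 to 9.05.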

Compound 3, acid dissociation constant: 8.67
Compound 3: middle estimate off by 0.08 log units, on the high side, and the stated range covers the measured number.
By their numbers in this assay, from the lowest: compounds 2, 3 and 1 (each within the scatter of the next).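

In this assay, going by these compounds alone, 2-hydroxyethyl in place of acetoxy on a saturated chain carbon, two bonds along the chain from a sulfonyl sulfur, gives a number 0.02 log units higher from compound 2 to compound 3 (within the scatter) and so provides the first direct reading of this change at this position. Exchanging acetoxy for a group that carries a hydrogen-bond donor leaves the read-out within the scatter in this one pair. Nothing measured here offers an explanation for this result. Going by these compounds, whether an amine, a carboxylic acid or a longer chain at this place would give a step beyond the scatter remains open.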